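Swapping the Cyclohexyl on Compound 2 for Hydroxyethyl

A few compounds are considered here, and "the series" means these few. Any claim that something is new, unique, unknown or untested is made for them only; others in the source may bear on it.

Of the compounds shown here, two sharing one core have been measured in an assay on Cerebral cortex for displacement of a labelled ligand from adenosine receptor A1 (Bos taurus); on this read-out lower numbers stand for stronger inhibition and higher numbers for weaker inhibition. Compound 1 `CNc1nc(-c2ccccc2)nc2c1nnn2Cc1ccccc1F` gives 25 nM. Compound 2 `Fc1ccccc1Cn1nnc2c(NC3CCCCC3)nc(-c3ccccc3)nc21` carries a cyclohexyl where compound 1 carries a methyl. In this assay, going by the values given here, compound 2 gives 1.15 nM and thus shows the lower of the two numbers; the one step measured so far, a 22-fold lower number from compound 1 to compound 2 (1.34 log units; beyond the scatter), is large and points to the group on this nitrogen as the place where the numbers move.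

Compound 3 `OCCNc1nc(-c2ccccc2)nc2c1nnn2Cc1ccccc1F` is not yet measured. It differs from compound 2 in one place: 2-hydroxyethyl in place of cyclohexyl on a nitrogen on an aromatic ring.

Among the compounds with values here, the only measured step that bears on this change is the one from compound 1 to compound 2. It shows that a small group on this nitrogen gave a much higher number than the cyclohexyl. A 2-hydroxyethyl is again a small group, so the expectation is that compound 3 gives back much of what compound 2 gained. Compound 3 is estimated at 30 nM, with a range from 8 nM to 120 nM, which would be a step of a 26-fold higher number from compound 2 to compound 3 (1.42 log units; beyond the scatter) and is expected to land near the number of compound 1.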

Compound 3, inhibition constant: 54 nM
Compound 3: middle estimate off by 1.8-fold (0.26 log units), on the low side; the measured number falls inside the stated range.
By their numbers in this assay, from the lowest: compound 2; then compound 1; then compound 3.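

In this assay, going by these compounds alone, putting 2-hydroxyethyl in place of cyclohexyl on this nitrogen gives a 47-fold higher number from compound 2 to compound 3 (1.67 log units; beyond the scatter) and thus a large loss, so methyl is no longer the only group seen to give a much higher number than cyclohexyl. Going from methyl to 2-hydroxyethyl gives a 2.2-fold higher number from compound 1 to compound 3 (0.33 log units; beyond the scatter) and thus only a modest change, even though the new group brings an oxygen, with one hydrogen-bond donor and one hydrogen-bond acceptor that cyclohexyl and methyl lack. No outside evidence is available to explain either step.

The step from compound 2 to compound 3 removes a ring and adds a hydroxyl group in a single change, so the compounds shown cannot say how much of the large step belongs to each. An unbranched ethyl chain would isolate the effect of the hydroxyl group against compound 3, while a cyclopentyl ring or a 4-hydroxycyclohexyl group would test whether a ring of another size, or a ring carrying a hydroxyl group, keeps the low number of compound 2.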